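This account rests on a few compounds, and the source may have more. Where it says the series, first, only, none or still open, it means among the compounds named here.

Compound 1 `CCCCCCn1ccc2cc(/C(C)=C/C(=O)Nc3ccccc3OCCCC(=O)O)ccc21` — 77 nM
Compound 2 `CCCC(C(C)C)n1ccc2cc(/C(C)=C/C(=O)Nc3ccccc3OCCCC(=O)O)ccc21` — 7.2 nM

For the measured compounds named here, in an assay on Prostate gland for inhibition of steroid 5-alpha-reductase (Rattus norvegicus) (a higher number here means a weaker inhibitor, a lower number a stronger inhibitor), compound 2 gives the lower of the two numbers, with compound 1 as its only neighbour at 77 nM. Compound 3 `C/C(=C\C(=O)Nc1ccccc1OCCCC(=O)O)c1ccc2c(ccn2Cc2ccc(C(F)(F)F)cc2)c1` differs from compound 2 by 4-(trifluoromethyl)benzyl in place of 1-isopropylbutyl on an aromatic nitrogen. Going by the values given here, the one measured step, an 11-fold lower number from compound 1 to compound 2 (1.03 log units; beyond the scatter), swapped one chain for another on the same nitrogen, so it does not speak directly to a benzyl group entering there. Among the compounds with values here, with no closer precedent, the step of a 2.1-fold higher number from compound 2 to compound 3 (0.32 log units; beyond the scatter) is expected to stay small, though the range is wide. Compound 3 is therefore estimated at 15 nM, between 4 nM and 60 nM.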

Compound 3, half-maximal inhibitory concentration: 300 nM
Compound 3: the middle estimate sits 20-fold (1.30 log units) below what was measured, outside the stated range (above it).
By their numbers in this assay, from the lowest: compound 2; then compound 1; then compound 3.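

In this assay, this nitrogen proves far less tolerant of a ring-bearing group than of a chain: a 42-fold higher number from compound 2 to compound 3 (1.62 log units; beyond the scatter) undoes the gain from branching, and a 3.9-fold higher number from compound 1 to compound 3 (0.59 log units; beyond the scatter) leaves the benzyl compound weaker even than the straight hexyl chain. Among these three groups, the 4-(trifluoromethyl)benzyl gives the highest number and the 1-isopropylbutyl the lowest. No measurement shown gives a reason for this.

Going by these compounds, it remains open whether the aromatic ring or the trifluoromethyl on it drives the change. A plain benzyl or a cyclohexylmethyl group on this nitrogen would help separate the two.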